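This account rests on a few compounds, and the source may have more. Where it says the series, first, only, none or still open, it means among the compounds named here.

Of the compounds shown here, three sharing one core have been measured in an assay on isolated protein for inhibition of histone deacetylase 4 (Homo sapiens), with a stated time of 1 h; on this read-out lower numbers stand for stronger inhibition and higher numbers for weaker inhibition. Compound 1 `O=C(COc1ccc2cc(/C=C3/SC(=O)NC3=O)ccc2c1)Nc1cc(Cl)cc(C(F)(F)F)c1` gives 4000 nM. Compound 2 `COc1cccc(NC(=O)COc2ccc3cc(/C=C4/SC(=O)NC4=O)ccc3c2)c1` gives 1600 nM, and compound 3 `O=C(COc1ccc2cc(/C=C3/SC(=O)NC3=O)ccc2c1)Nc1ccc(Cl)c(Cl)c1` gives 5500 nM. Compound 1 thus holds the second highest of the three numbers; its step to compound 3 stays within the scatter, a 1.4-fold higher number from compound 1 to compound 3 (0.14 log units; within the scatter), while its step to compound 2 goes beyond it, a 2.5-fold lower number from compound 1 to compound 2 (0.40 log units; beyond the scatter). The remaining pair also lies beyond the scatter, a 3.4-fold higher number from compound 2 to compound 3 (0.54 log units; beyond the scatter).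

Compound 4 `O=C(COc1ccc2cc(/C=C3/SC(=O)NC3=O)ccc2c1)Nc1cccc(C(F)(F)F)c1` has not yet been measured in this assay. It differs from compound 1 in one place: hydrogen in place of chloro on an aromatic carbon. Among the measured compounds shown here, none of the measured steps removes a chloro alone; all three exchange the whole group on the amide-type nitrogen. For the measured compounds named here, the step closest in kind, a 1.4-fold higher number from compound 1 to compound 3 (0.14 log units; within the scatter), in which one chloro-bearing group replaced another, stayed within the scatter, and the only step beyond it, a 2.5-fold lower number from compound 1 to compound 2 (0.40 log units; beyond the scatter), was modest. A change as small as losing one chloro is therefore expected to move the number only a little, if at all, perhaps slightly downward. Compound 4 is estimated at 3000 nM, with a range of 1500 nM to 6000 nM. The expected step is a 1.3-fold lower number from compound 1 to compound 4 (0.12 log units; within the scatter), which is within the usual scatter.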

Compound 4, half-maximal inhibitory concentration: 2500 nM
Estimate against measurement, compound 4: 1.2-fold (0.08 log units) above, within the range that was stated.
By their numbers in this assay, from the lowest: compounds 2, 4, 1 and 3 (each within the scatter of the next, the first and the last beyond it).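

Among the compounds shown here, removing only the chloro from the aromatic carbon meta to a trifluoromethyl group gives a 1.6-fold lower number from compound 1 to compound 4 (0.20 log units; within the scatter) in this assay, so this single atom, tested alone for the first time, has no effect that can be told from the scatter. Without the chloro, however, the 3-(trifluoromethyl)phenyl group does separate from the 3,4-dichlorophenyl group, with a 2.2-fold lower number from compound 3 to compound 4 (0.34 log units; beyond the scatter), a modest step, although the chloro-bearing group of compound 1 could not be separated from that of compound 3. Exchanging methoxy for trifluoromethyl on an aromatic carbon gives a 1.6-fold higher number from compound 2 to compound 4 (0.19 log units; within the scatter), so these two groups cannot be told apart here, even though compound 2 stands clearly apart from compound 1 and compound 3.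

No measurement shown here accounts for the size of any of these steps. The compounds leave open what a group of a different kind would do on this aromatic ring, such as an amine or a carboxylic acid in place of the trifluoromethyl group, and whether a longer chain there would move the number beyond the scatter.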